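A few compounds are considered here, and "the series" means these few. Any claim that something is new, unique, unknown or untested is made for them only; others in the source may bear on it.

Measured so far in a functional assay on CHO cells for agonist activity at Alpha-2C adrenergic receptor (Homo sapiens); on this read-out higher numbers stand for larger maximal responses and lower numbers for smaller maximal responses:
compound 1 `CC(Oc1ccccc1-c1ccc([N+](=O)[O-])cc1)C1=NCCN1`: < 0.3
compound 2 `Cc1ccccc1-c1ccccc1OC(C)C1=NCCN1`: 0.45
compound 3 `CC(Oc1ccccc1-c1cccs1)C1=NCCN1`: 0.8

Compound 3 holds the higher of the two numbers obtained; compound 2 sits beneath it by a number 0.35 higher from compound 2 to compound 3 (beyond the scatter), a large rise. The value of compound 1 is a limit of the assay rather than a number, (the limit of < 0.3 in this assay, at which 1 of the 3 values shown sits).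

Compound 4 `CC(Oc1ccccc1-c1ccc(O)cc1)C1=NCCN1` has not yet been measured. It differs from compound 3 by 4-hydroxyphenyl in place of thiophen-2-yl on an aromatic carbon. For the measured compounds named here, one measured step bears on this position: a number 0.35 higher from compound 2 to compound 3 (beyond the scatter), in which a six-membered ring of carbon only gave way to a five-membered aromatic ring with one hetero atom. Compound 4 runs that change in reverse, bringing a six-membered ring of carbon only back. Compound 1, which also carries a six-membered ring of carbon only at this position, reaches only a limit. A step downward beyond the scatter is therefore expected for compound 4, about a number 0.30 lower from compound 3 to compound 4 (beyond the scatter). Compound 4 is estimated at 0.5, likely between 0.3 and 0.7.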

Compound 4, intrinsic activity: the largest response reached, as a fraction of the reference agonist's: < 0.3
Compound 4: only a limit was reported; the forecaster's own chance of this, stated with the estimate: 25%; middle value at least 0.20 away from the limit.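

In this assay, placing 4-hydroxyphenyl on this aromatic carbon in place of thiophen-2-yl gives a number at least 0.50 lower from compound 3 to compound 4 (beyond the scatter). The six-membered rings also differ among themselves: 4-hydroxyphenyl in place of 2-methylphenyl gives a number at least 0.15 lower from compound 2 to compound 4 (beyond the scatter), so a six-membered aromatic ring of carbon only does not by itself set the maximal response. Compound 4 and compound 1 each report a limit rather than a number, and the step between them cannot be read: the limit of < 0.3 in this assay, at which 2 of the 4 values shown sit.

The compounds shown leave open whether a phenyl ring carrying an amine or a methoxy group in place of hydroxy or nitro would give a maximal response nearer that of compound 3. They also leave open whether a furan ring, another five-membered aromatic ring with one hetero atom, would match thiophen-2-yl.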